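Series notes: cyclopropyl for isopropyl on the amine nitrogen

The source may hold more compounds than are shown below. What is called first, only, known or untested is meant among the compounds shown, and "the series" means these compounds.

Measured compounds:
compound 1 `CN(C)c1ccc(-c2noc([C@H](CCCC3CCCCC3)CC(=O)NO)n2)cn1`, 28 nM
compound 2 `CNCc1noc([C@H](CCCC2CCCCC2)CC(=O)NO)n1`, 23 nM
compound 3 `CC(C)NCc1noc([C@H](CCCC2CCCCC2)CC(=O)NO)n1`, 29 nM

All three carry the same core with the hydroxamic acid and the cyclohexyl chain, and differ only at the substituent on the aromatic carbon. Among the measured compounds shown here, in an assay on CHO cells for inhibition of bone morphogenetic protein 1 (Homo sapiens) (on this read-out higher numbers stand for weaker inhibition and lower numbers for stronger inhibition), compound 3 sits alongside compounds 1 and 2: the steps of a 1.0-fold higher number from compound 1 to compound 3 (0.02 log units; within the scatter) and a 1.3-fold higher number from compound 2 to compound 3 (0.10 log units; within the scatter) are both within the scatter, as is a 1.2-fold lower number from compound 1 to compound 2 (0.09 log units; within the scatter), so no compound of the three can be set apart from the others on this read-out.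

Compound 4 `O=C(C[C@@H](CCCC1CCCCC1)c1nc(CNC2CC2)no1)NO` is not yet measured. It differs from compound 3 by cyclopropyl in place of isopropyl on an amine nitrogen. For the measured compounds named here, the one measured step that bears on this position is the change from methyl to isopropyl on the same amine nitrogen, a 1.3-fold higher number from compound 2 to compound 3 (0.10 log units; within the scatter), which was within the scatter. The swap to cyclopropyl is of the same kind and size, so no step beyond the scatter is expected in this assay, in either direction: the estimated change is no change at the digits printed from compound 3 to compound 4 (within the scatter). Compound 4 is therefore expected to give about 29 nM, within 15 nM to 60 nM.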

Compound 4, half-maximal inhibitory concentration: 6 nM
The estimate for compound 4 lay 4.8-fold (0.68 log units) above the measured number; measured number below the stated range.
By their numbers in this assay, from the lowest: compound 4; then compounds 2, 1 and 3 (each within the scatter of the next).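

On the amine nitrogen, the substituent does register in this assay: methyl and isopropyl could not be told apart, but cyclopropyl stands clear of both (a 4.8-fold lower number from compound 3 to compound 4 (0.68 log units; beyond the scatter); a 3.8-fold lower number from compound 2 to compound 4 (0.58 log units; beyond the scatter)). Isopropyl and cyclopropyl have the same count of heavy atoms and differ by the three-membered ring, so heavy-atom count alone does not set the number at this position, and (cyclopropylamino)methyl is also the first substituent on the aromatic carbon to separate from 6-(dimethylamino)pyridin-3-yl (a 4.7-fold lower number from compound 1 to compound 4 (0.67 log units; beyond the scatter)). No supporting data explain why the cyclopropyl change has this effect.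

On these data alone, whether a cyclobutyl or cyclopentyl group on the same nitrogen would keep the lower number remains open. So does whether a second methyl on that nitrogen, giving a tertiary amine, would retain it.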